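The source may hold more compounds than are shown below. What is called first, only, known or untested is meant among the compounds shown, and "the series" means these compounds.

Working notes on the series.

Compound 1 `COc1cc2nc(N3CCN(S(=O)(=O)c4ccccc4[N+](=O)[O-])CC3)nc(N)c2cc1OC` is tested in a functional assay on PC-3 cells (Homo sapiens) for inhibition (on this read-out higher numbers stand for weaker inhibition and lower numbers for stronger inhibition), where compound 1 gives 35000 nM. Compound 2 `COc1ccc(S(=O)(=O)N2CCN(c3nc(N)c4cc(OC)c(OC)cc4n3)CC2)cc1`, carrying 4-methoxyphenyl in place of 2-nitrophenyl on the sulfonyl sulfur, gives 39000 nM; that step is a 1.1-fold higher number from compound 1 to compound 2 (0.05 log units; within the scatter). Compound 3 `COc1cc2nc(N3CCN(S(=O)(=O)c4cccc5c(N(C)C)cccc45)CC3)nc(N)c2cc1OC` gives 29000 nM. Compound 2 thus stands among three numbers that all lie within the scatter of one another, so nothing separates it from compound 1 or compound 3.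

Compound 4 `COc1cc2nc(N3CCN(S(=O)(=O)c4ccc(-c5ccccc5)cc4)CC3)nc(N)c2cc1OC` is not yet measured. Its difference from compound 2 is phenyl in place of methoxy on an aromatic carbon; cut one bond further out, this reads 4-methoxyphenyl to 4-phenylphenyl.

Among the compounds with values here, only the step from compound 1 to compound 2 bears on this position, as it also exchanges the aryl group on the sulfonyl sulfur; it was a 1.1-fold higher number from compound 1 to compound 2 (0.05 log units; within the scatter), and the step to compound 3, which alters the same part, also stays within the scatter. Three quite different aryl groups at this position therefore give numbers that cannot be told apart, so for compound 4 no step beyond the scatter is expected in either direction; the expected step is a 1.1-fold lower number from compound 2 to compound 4 (0.05 log units; within the scatter).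

The estimate for compound 4 is 35000 nM, with a range from 15000 nM to 80000 nM.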

Compound 4, half-maximal inhibitory concentration: 4200 nM
The estimate for compound 4 lay 8.3-fold (0.92 log units) above the measured number, and the stated range ends above it.
By their numbers in this assay, from the lowest: compound 4; then compounds 3, 1 and 2 (each within the scatter of the next).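

In this assay, within the data shown here, the aryl group on the sulfonyl sulfur proves not to be a silent position: 4-phenylphenyl in place of 4-methoxyphenyl gives the first step beyond the scatter (a 9.3-fold lower number from compound 2 to compound 4 (0.97 log units; beyond the scatter)), and 4-phenylphenyl in place of 2-nitrophenyl gives a step of similar reach (an 8.3-fold lower number from compound 1 to compound 4 (0.92 log units; beyond the scatter)). Among these compounds, the flat picture from the earlier compounds therefore holds only for the aryl groups of compound 1, compound 2 and compound 3, and it ends once phenyl stands on the aromatic carbon para to a large group, with compound 4 alone lying beyond the scatter of compound 1 and compound 2. Nothing at hand bears on what lies behind this step.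

Compound 4 is the only compound shown with phenyl at this place, so it remains open whether the step belongs to the aromatic ring itself or would also follow from another group of similar size, such as cyclohexyl or benzyloxy. Also open, on these data alone, is how a carboxylic acid or an amine on the outer phenyl ring would read in this assay and whether the step survives such a change.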